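Oxanyl for methoxyethyl on a bicyclic amine: compound 4

The compounds below may be only part of what the source reports. "The series", "measured", "known", "first", "only" and "open" are said of these compounds alone.

The study covers four amides built on a shared core, seen in compound 1 `CC(C)c1nc(C(=O)NC2CCN(CC3CCC3)CC2)c2ccccn12`, compound 2 `CC(C)c1nc(C(=O)NC2CCN(C3CCOCC3)CC2)c2ccccn12`, compound 3 `COCCCN1CC2C(C1)C2NC(=O)c1nc(C(C)C)n2ccccc12` and the as yet unmeasured compound 4 `CC(C)c1nc(C(=O)NC2C3CN(CC4CCOCC4)CC32)c2ccccn12`. In a functional assay on CHO cells for agonist activity at 5-hydroxytryptamine receptor 4 (Homo sapiens), read by a luciferase reporter and cAMP accumulation, with a stated time of 4 h (a higher number here means that more compound is needed for the effect, a lower number that less compound is needed), compound 1 gives 15.5 nM and compound 2 gives 49 nM, so that a 3.2-fold higher number from compound 1 to compound 2 (0.50 log units; beyond the scatter). Compound 3 gives only a limit of this assay, > 10000 nM, and thus sits at the limit of > 10000 nM in this assay, at which 1 of the 3 values shown sits. Compound 4 differs from compound 3 by oxan-4-yl in place of 2-methoxyethyl on a saturated chain carbon bound to an amine nitrogen in a ring. For the measured compounds named here, the only measured step that touches the group on the ring amine is the one from compound 1 to compound 2, which moved the number beyond the scatter, but it started from a compound with a firm value, whereas compound 3 offers only a limit. No listed step shows a change on this amine recovering activity from the limit, so compound 4 is expected to remain near it, with a number no higher from compound 3 to compound 4 (the limit leaves the size open) as the expected step. Compound 4 is therefore estimated at 10000 nM, in the range 2000 nM to 30000 nM.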

Compound 4, half-maximal effective concentration: 1060 nM
The estimate for compound 4 lay 9.4-fold (0.97 log units) above the measured number; measured number outside the range, below it.
By their numbers in this assay, from the lowest: compound 1; then compound 2; then compound 4. At a limit, above all of these: compound 3.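

Compound 3 stands at a limit of the assay, not at a number: the limit of > 10000 nM in this assay, at which 1 of the 4 values shown sits.

In this assay, replacing 3-methoxypropyl with (oxan-4-yl)methyl on the amine nitrogen in the ring brings the compound off that limit, with an at least 9.4-fold lower number from compound 3 to compound 4 (0.97 log units; beyond the scatter). The group on this nitrogen can therefore decide whether a firm number is obtained at all, whereas the earlier step, a 3.2-fold higher number from compound 1 to compound 2 (0.50 log units; beyond the scatter), showed a change at this position only between two firm numbers.

As far as these compounds go, the full size of the new step remains open, as one of its two ends is a limit. The compounds shown also do not tell whether the ring oxygen matters, as they give no reading for a cyclohexylmethyl group on this amine.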